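From 2-methoxyphenyl to 4-methoxyphenyl: working notes

This account rests on a few compounds, and the source may have more. Where it says the series, first, only, none or still open, it means among the compounds named here.

Measured in a functional assay on HT-1080 cells (Homo sapiens) for cytotoxicity, read by MTT assay, with a stated time of 72 h; a lower number here means a stronger inhibitor, a higher number a weaker inhibitor:
compound 1 `COc1ccc(/C=C2\CCC/C(=C\c3ccc(Br)cc3)C2=O)cc1OC` gives 4300 nM
compound 2 `COc1ccccc1/C=C1\CCC/C(=C\c2ccc(OC)c(OC)c2)C1=O` gives 8100 nM

In this assay, compound 2 stands at 8100 nM, level with compound 1 within the scatter. Only these two numbers are available, and neither can be ranked above the other.

Next in the series is compound 3 `COc1ccc(/C=C2\CCC/C(=C\c3ccc(OC)c(OC)c3)C2=O)cc1`, which has the same atoms as compound 2, joined differently: 4-methoxyphenyl in place of 2-methoxyphenyl on a double-bonded chain carbon bound to a double-bonded ring carbon. It carries 4-methoxyphenyl in place of 2-methoxyphenyl on a double-bonded chain carbon bound to a double-bonded ring carbon.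

Within the data shown here, one measured step bears on this place: a 1.9-fold higher number from compound 1 to compound 2 (0.28 log units; within the scatter). That step put 2-methoxyphenyl in place of 4-bromophenyl and stayed within the scatter. Among the measured compounds shown here, no measured compound carries 4-methoxyphenyl at this place, and one step gives only a thin basis for any direction. No step beyond the scatter is therefore expected in this assay.

The estimated step is a 1.4-fold lower number from compound 2 to compound 3 (0.13 log units; within the scatter). For compound 3 the expected value is 6000 nM, with an estimated range of 2500 nM to 14000 nM.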

Compound 3, half-maximal inhibitory concentration: 7200 nM
Compound 3: middle estimate off by 1.2-fold (0.08 log units), on the low side, within the range that was stated.
By their numbers in this assay, from the lowest: compounds 1, 3 and 2 (each within the scatter of the next).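

In this assay, the earlier step changed two things at once at this place, the group on the phenyl and where it sat, and compound 3 separates them. Taken alone, 4-methoxyphenyl in place of 2-methoxyphenyl on a double-bonded chain carbon bound to a double-bonded ring carbon stays within the scatter (a 1.1-fold lower number from compound 2 to compound 3 (0.05 log units; within the scatter)), and so does methoxy in place of bromo on an aromatic carbon (a 1.7-fold higher number from compound 1 to compound 3 (0.22 log units; within the scatter)). Neither change therefore separates these compounds in this cytotoxicity read-out, and no measurement at hand offers an explanation for that.

Going by these compounds, three compounds carrying only methoxy or bromo on this phenyl cover a narrow set of groups, so it stays open whether any group at this place can give a step beyond the scatter. On these data alone, a dimethylamino group, a carboxylic acid or a longer alkoxy chain in place of the methoxy would test this, and whether the other dimethoxyphenyl arm of the shared core tolerates change as well also remains unknown.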